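Thiazole series: dropping the arylazo group before cytotoxicity data

A few compounds are considered here, and "the series" means these few. Any claim that something is new, unique, unknown or untested is made for them only; others in the source may bear on it.

Compound 1 `Cc1nc(N2Nc3onc(-c4ccccc4)c3C2c2ccc(Cl)cc2)sc1/N=N/c1ccc(Cl)cc1` and compound 2 `COc1ccc(/N=N/c2sc(N3Nc4onc(-c5ccccc5)c4C3c3ccc(Cl)cc3)nc2C)cc1` share the same core and differ only in one substituent on the outer aromatic ring. In an ADME assay on MT4 cells (Homo sapiens) for cytotoxicity, read by MTT assay (on this read-out lower numbers stand for higher toxicity in this test and higher numbers for lower toxicity in this test), compound 1 gives 340 nM, and compound 2 gives 460 nM. The step of a 1.4-fold higher number from compound 1 to compound 2 (0.13 log units; within the scatter). Compound 2 therefore sits with compound 1 inside the usual scatter, and no other number in this assay stands beside it. Compound 3 `Cc1csc(N2Nc3onc(-c4ccccc4)c3C2c2ccc(Cl)cc2)n1` is not yet measured. Its difference from compound 2: a hydrogen atom in place of a group of 10 heavy atoms (7 carbon, 2 nitrogen, 1 oxygen; one six-membered aromatic ring of carbon only), on an aromatic carbon. Among the measured compounds shown here, only the step from compound 1 to compound 2 is known, and it bears weakly on this change: it alters one substituent of the group that is removed here, whereas compound 3 loses the whole group. An expected step of a 2.6-fold higher number from compound 2 to compound 3 (0.42 log units; beyond the scatter) rests on the size of the structural change alone, with its direction uncertain. Compound 3 is expected at 1200 nM, within 300 nM to 5000 nM.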

Compound 3, half-maximal cytotoxic concentration: 230 nM
The estimate for compound 3 lay 5.2-fold (0.72 log units) above the measured number; measured number outside the range, below it.
By their numbers in this assay, from the lowest: compounds 3, 1 and 2 (each within the scatter of the next).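

In this assay, a hydrogen atom in place of the group of 10 heavy atoms, on the aromatic carbon next to the ring sulfur, gives a 2.0-fold lower number from compound 2 to compound 3 (0.30 log units; within the scatter), and a hydrogen atom in place of the chlorine-bearing group at that same carbon gives a 1.5-fold lower number from compound 1 to compound 3 (0.17 log units; within the scatter). Among the compounds shown here, the earlier pair changed only one substituent on this group, whereas these steps show that the entire group can be replaced by hydrogen with all three numbers remaining within the scatter of their neighbours. No evidence at hand bears on what lies behind this result.

Open, going by these compounds, is whether a small group at this carbon, such as an amine, a carboxylic acid or a longer alkyl chain, would also stay within the scatter. Also open, on these data alone, is how the methyl group on the neighbouring ring atom contributes to these numbers.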